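A few compounds are considered here, and "the series" means these few. Any claim that something is new, unique, unknown or untested is made for them only; others in the source may bear on it.

Measured so far in an ADME assay on the whole organism (plasma, Rattus norvegicus) for protein binding, using cassette dosing, at a dose of 1 mg/kg; on this read-out higher numbers stand for a larger free fraction and lower numbers for a smaller free fraction:
- compound 1 `Cc1cc(/N=c2\[nH]c(=O)n(C[C@H](C)C(=O)O)c(=O)n2Cc2ccc(Cl)cc2)ccc1OC(C)C` gives 0.02
- compound 2 `CC(C)Oc1ccc(/N=c2\[nH]c(=O)n(C[C@@H](O)CO)c(=O)n2Cc2ccc(Cl)cc2)cc1Cl` gives 0.001
- compound 3 `C[C@@H](Cn1c(=O)[nH]/c(=N\c2ccc(Oc3cccc(F)n3)cc2)n(Cc2ccc(Cl)cc2)c1=O)C(=O)O` gives 0.007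

Compound 2 stands lowest of the three in this assay, and its gaps to compound 3 and to compound 1 both lie beyond the scatter. The next compound for this measurement is compound 4 `CC(C)Oc1ccc(/N=c2\[nH]c(=O)n(C[C@H](C)C(=O)O)c(=O)n2Cc2ccc(Cl)cc2)cc1Cl`. The structural change from compound 2 is 1-carboxyethyl in place of 1,2-dihydroxyethyl on a saturated chain carbon bound to an aromatic nitrogen, with 1-carboxyethyl in place of 1,2-dihydroxyethyl on a saturated chain carbon bound to an aromatic nitrogen. For the measured compounds named here, no measured pair isolates this change, so the evidence is indirect. Compound 1 at 0.02 and compound 3 at 0.007 both carry the 2-carboxypropyl chain and both stand higher than compound 2, although each also differs from compound 4 elsewhere in the structure. An upward move beyond the scatter is therefore expected, estimated as a 10-fold higher number from compound 2 to compound 4 (1.00 log units; beyond the scatter) in this assay here. For compound 4 the expected value is 0.01, with an estimated range from 0.004 to 0.03 as the working expectation.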

Compound 4, unbound fraction: 0.003
Beside the measured number, compound 4's estimate is 3.3-fold (0.52 log units) above it; the whole stated range lies above it.
By their numbers in this assay, from the lowest: compound 2; then compound 4; then compound 3; then compound 1.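

In this assay, for the compounds shown here, the first matched comparison at this position gives a 3.0-fold higher number from compound 2 to compound 4 (0.48 log units; beyond the scatter) for 2-carboxypropyl in place of 2,3-dihydroxypropyl on a saturated chain carbon bound to an aromatic nitrogen, so this change alone moves the free fraction upward beyond the scatter. With the 2-carboxypropyl chain held constant, a 6.7-fold lower number from compound 1 to compound 4 (0.82 log units; beyond the scatter) for chloro in place of methyl on an aromatic carbon, so the chain is not the only place in the series that moves this read-out. Nothing on hand gives a reason for either step.

Still open, as far as these compounds go, is how an amine or a primary amide would read on this chain. Also open, from the compounds shown here alone, is whether the chloro and methyl step recurs with the 2,3-dihydroxypropyl chain in place of 2-carboxypropyl.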